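This account rests on a few compounds, and the source may have more. Where it says the series, first, only, none or still open, it means among the compounds named here.

Compound 1 `CC(C)=CC[C@@H](OC(=O)C1CCOC1)C1=CC(=O)c2c(O)ccc(O)c2C1=O` gives 47500 nM in a functional assay on DU-145 cells (Homo sapiens) for cytotoxicity, read by MTT assay; on this read-out lower numbers stand for stronger inhibition and higher numbers for weaker inhibition. Among the two numbers reported, compound 1 holds the higher one; its nearest neighbour is compound 3 `COCCO[C@H](CC=C(C)C)C1=CC(=O)c2c(O)ccc(O)c2C1=O`, which in this assay gives 43200 nM, and the step between them lies within the scatter a 1.1-fold lower number from compound 1 to compound 3 (0.04 log units; within the scatter). Compound 2 `CCCC(O)CC(=O)O[C@H](CC=C(C)C)C1=CC(=O)c2c(O)ccc(O)c2C1=O` reaches only a limit in this assay, namely > 100000 nM (the limit of > 100000 nM in this assay, at which 1 of the 3 values shown sits). Compound 4 `CC(C)=CC[C@@H](OC(=O)CC(C)(O)C(C)C)C1=CC(=O)c2c(O)ccc(O)c2C1=O` has not yet been measured. It differs from compound 1 in one place: 2-hydroxy-2,3-dimethylbutyl in place of oxolan-3-yl on a carbonyl carbon. Most relevant is an at least 2.1-fold higher number from compound 1 to compound 2 (0.32 log units; beyond the scatter), a step that came from putting 2-hydroxypentyl in place of oxolan-3-yl on a carbonyl carbon. The 2-hydroxy-2,3-dimethylbutyl group of compound 4 is likewise an open-chain hydroxyalkyl group in the same place, so for compound 4 a rise of similar size is expected a 1.8-fold higher number from compound 1 to compound 4 (0.25 log units; within the scatter), and it may well reach the limit. Compound 4 is therefore estimated at 85000 nM, expected to lie between 40000 nM and 180000 nM.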

Compound 4, half-maximal inhibitory concentration: 16900 nM
Compound 4: middle estimate off by 5.0-fold (0.70 log units), on the high side; the measured number lies below the stated range.
By their numbers in this assay, from the lowest: compound 4; then compounds 3 and 1 (each within the scatter of the next). At a limit, above all of these: compound 2.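

On the carbonyl carbon, an open-chain group carrying a hydroxyl does not by itself weaken the result in this assay: 2-hydroxypentyl gave an at least 2.1-fold higher number from compound 1 to compound 2 (0.32 log units; beyond the scatter), whereas 2-hydroxy-2,3-dimethylbutyl gives a 2.8-fold lower number from compound 1 to compound 4 (0.45 log units; beyond the scatter). The new group also stands clear of the 2-methoxyethyl group on the oxygen, with a 2.6-fold lower number from compound 3 to compound 4 (0.41 log units; beyond the scatter), so compound 4 now has the lowest number of those shown. The two open-chain groups differ in the opposite direction from what their shared hydroxyl might suggest, with an at least 5.9-fold lower number from compound 2 to compound 4 (0.77 log units; beyond the scatter), and compound 2 stands only at a limit: the limit of > 100000 nM in this assay, at which 1 of the 4 values shown sits.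

The compounds shown do not separate the part played by the branching from that of the hydroxyl group. A 2,3-dimethylbutyl group without the hydroxyl, or the same branched chain with an amine in its place, would bear on this.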